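Trifluoromethyl removal from compound 1: working notes

The compounds below may be only part of what the source reports. "The series", "measured", "known", "first", "only" and "open" are said of these compounds alone.

Measured in a functional assay on HUVEC cells (Homo sapiens) for antiproliferative activity, read by MTT assay, with a stated time of 24 h; on this read-out lower numbers stand for stronger inhibition and higher numbers for weaker inhibition:
- compound 1 `C=CCc1cc(-c2cccc(C(F)(F)F)c2)ccc1O`: 76000 nM
- compound 2 `C=CCc1cc(C=O)c(OCC(=O)OCC)c(-c2ccc(OCC(=O)OCC)c(CC=C)c2)c1`: 86900 nM
- compound 3 `C=CCc1cc(-c2ccc(OC)cc2)cc(CC=C)c1O`: > 100000 nM (a limit of the assay)

Within the data shown here, compound 1 and compound 2 carry the only two numeric values, and these lie within the scatter of each other. Compound 3 gives only a limit.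

Compound 4 `C=CCc1cc(-c2ccccc2)ccc1O` has hydrogen in place of trifluoromethyl on an aromatic carbon, meta to a large group: hydrogen in place of trifluoromethyl on an aromatic carbon. Among the measured compounds shown here, no measured pair gauges this change, so the expectation rests on compound 1 at 76000 nM. The estimated 1.1-fold higher number from compound 1 to compound 4 (0.02 log units; within the scatter) is expected to stay within the scatter in this assay. For compound 4 the estimated value is 80000 nM, with an expected range of 35000 nM to 100000 nM.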

Compound 4, half-maximal inhibitory concentration: > 100000 nM
Compound 4 was reported as a limit; the forecaster's own chance of this, stated with the estimate: 30%; middle value at least 1.2-fold (0.09 log units) from the limit.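

Among these compounds, the first direct reading of hydrogen in place of trifluoromethyl on this aromatic carbon in this assay is an at least 1.3-fold higher number from compound 1 to compound 4 (0.11 log units; that floor lies within the scatter). Compound 4 gives > 100000 nM, which is a limit of the assay and not a number. The step therefore has a floor but no upper end, so its true size stays unknown: the limit of > 100000 nM in this assay, at which 2 of the 4 values shown sit.

Open, going by these compounds, is how an amine or a carboxylic acid on this same aromatic carbon would read in this assay against trifluoromethyl and hydrogen.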